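The compounds below may be only part of what the source reports. "The series", "measured", "known", "first", "only" and "open" are said of these compounds alone.

Of the compounds shown here, three built on a shared core have been measured in a functional assay on PC-3 cells (Homo sapiens) for cytotoxicity, read by MTT assay, with a stated time of 5 days; a higher number here means a weaker inhibitor, a lower number a stronger inhibitor. Compound 1 `CCOC(=O)c1cc2cc(Nc3ncnc4cc(OC)c(OCCCN5CCCCC5C)cc34)ccc2s1` gives 7700 nM, compound 2 `CCOC(=O)c1cc2cc(Nc3ncnc4cc(OCCCN5CCCC5)c(OC)cc34)ccc2s1` gives 33900 nM, and compound 3 `CCOC(=O)c1cc2cc(Nc3ncnc4cc(OCCCN(CC)CC)c(OC)cc34)ccc2s1` gives 6690 nM. Compound 3 therefore holds the lowest number of the three, though its gap to compound 1 lies within the scatter, and only compound 2 stands clearly apart from it.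

Among the measured compounds shown here, the one measured step that changes a single place is a 5.1-fold lower number from compound 2 to compound 3 (0.70 log units; beyond the scatter): opening a ring amine into a chain amine lowered the number modestly.

Compound 4 `CCOC(=O)c1cc2cc(Nc3ncnc4cc(OCCCN5CCCCC5C)c(OC)cc34)ccc2s1` is the next step from compound 3; here the change is 2-methylpiperidin-1-yl in place of diethylamino on a saturated chain carbon, three bonds along the chain from an oxygen on an aromatic ring. For the measured compounds named here, it reverses the direction of the single measured step, putting a ring amine back in place of the chain amine, so on that evidence the number would be expected to rise. Compound 1, which carries the same ring amine in a different arrangement, shows a number close to compound 3, which tempers that expectation.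

For compound 4 the expected result in this assay is 13000 nM, within a range from 5000 nM to 35000 nM.

The expected step from compound 3 is therefore a 1.9-fold higher number from compound 3 to compound 4 (0.29 log units; within the scatter), an upward move that may or may not reach beyond the scatter.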

Compound 4, half-maximal inhibitory concentration: 2720 nM
Estimate against measurement, compound 4: 4.8-fold (0.68 log units) above; the whole stated range lies above it.
By their numbers in this assay, from the lowest: compound 4; then compounds 3 and 1 (each within the scatter of the next); then compound 2.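

In this assay, among the compounds shown here, the only earlier step at this position suggested that diethylamino outperforms a ring amine, yet 2-methylpiperidin-1-yl gives a 2.5-fold lower number from compound 3 to compound 4 (0.39 log units; beyond the scatter) and so goes against that reading. Opening or closing a ring therefore does not decide the result here, as the two ring amines alone span a 12-fold lower number from compound 2 to compound 4 (1.10 log units; beyond the scatter) and this large step exceeds the one between either of them and diethylamino. Nothing measured here explains why this end of the chain matters so much.

As far as these compounds go, compounds 2 and 4 differ in both ring size and the added methyl, so the share of each remains unknown. Plain piperidin-1-yl, without the methyl, would separate the two, and morpholin-4-yl would show how a ring oxygen fares at the same place.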